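A few compounds are considered here, and "the series" means these few. Any claim that something is new, unique, unknown or untested is made for them only; others in the source may bear on it.

Compound 1 `O=C(/C=C/c1ccc(/C=C/C(=O)c2ccccc2)o1)NO` gives 13300 nM in a functional assay on PC-3 cells (Homo sapiens) for antiproliferative activity, read by MTT assay, with a stated time of 48 h (a higher number here means a weaker inhibitor, a lower number a stronger inhibitor), and serves as the unsubstituted reference for this small series. Compound 3 `COc1ccc2cc(C(=O)/C=C/c3ccc(/C=C/C(=O)NO)o3)ccc2c1` reads 36300 nM on the same scale and stands at the weak end, while compound 2 `O=C(/C=C/c1ccc(/C=C/C(=O)c2ccc(Cl)cc2)o1)NO` reads 1350 nM and is the strongest of the three. The next compound to consider is compound 4 `Cc1ccc(C(=O)/C=C/c2ccc(/C=C/C(=O)NO)o2)cc1`, which carries methyl in place of chloro on an aromatic carbon, para to a large group, and the counted difference is methyl in place of chloro on an aromatic carbon with nothing else altered. Within the data shown here, one measured step bears on this change, namely a 9.9-fold lower number from compound 1 to compound 2 (0.99 log units; beyond the scatter) when chloro takes the place of hydrogen at that same carbon. Among the measured compounds shown here, no measured step covers methyl, so how much of that gain survives the exchange remains open. In this assay compound 4 is therefore expected to lose part of that step, with a number higher than that of compound 2 yet probably no higher than that of compound 1. The expected change is a 3.0-fold higher number from compound 2 to compound 4 (0.47 log units; beyond the scatter) and would be modest in size. For compound 4 the estimate is 4000 nM with an expected range from 1200 nM to 14000 nM as the likely span.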

Compound 4, half-maximal inhibitory concentration: 16000 nM
The estimate for compound 4 lay 4.0-fold (0.60 log units) below the measured number; measured number above the stated range.
By their numbers in this assay, from the lowest: compound 2; then compounds 1 and 4 (each within the scatter of the next); then compound 3.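

In this assay the exchange of chloro for methyl on this aromatic carbon, para to a large group, gives a 12-fold higher number from compound 2 to compound 4 (1.07 log units; beyond the scatter) and so removes the whole gain that chloro had brought over the unsubstituted reference. Methyl set against hydrogen at the same carbon gives a 1.2-fold higher number from compound 1 to compound 4 (0.08 log units; within the scatter) and stays within the scatter, so the two cannot be told apart at this position. The earlier compounds shown here showed only that chloro outdid hydrogen here; this pair shows that a single heavy atom at this carbon does not by itself give the gain, since methyl, also counted as one heavy atom, leaves the number where hydrogen had it. No measurement among the data bears on why chloro and methyl part so sharply at this carbon.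

The compounds shown leave open whether the gain belongs to chloro alone or would also appear with fluoro, bromo, methoxy or a nitrile at this carbon. They also leave open whether chloro would give the same step at another carbon of this six-membered aromatic ring.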